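The source may report more compounds than this note shows. Statements on the series, on what has been measured and on what is new or still open speak of the compounds shown alone.

Three compounds share one core here: compound 1 `Cc1cc(O)cc(S(=O)(=O)c2cccc(N)c2C#N)c1`, compound 2 `COc1cccc(S(=O)(=O)c2cccc(N)c2C#N)c1` and compound 3 `Cc1cccc(S(=O)(=O)c2cccc(N)c2C#N)c1`. In a functional assay on MT4 cells (Homo sapiens) for cytotoxicity (a lower number here means a stronger inhibitor, a higher number a weaker inhibitor), compound 1 gives 167000 nM. In this assay, compound 2 gives > 200000 nM, and this is a limit of the assay, not a number. From the compounds shown here alone, compound 2 therefore stands at the limit of > 200000 nM in this assay, at which 1 of the 2 values shown sits, so its exact value remains unknown.

Compound 3 differs from compound 2 in a single place, with methyl in place of methoxy on an aromatic carbon. Among the measured compounds shown here, no measured pair of compounds shows directly what this swap does, which leaves only a weak basis for a forecast. The best guide is compound 1, which also carries a methyl and gives 167000 nM.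

The expected step of an at least 1.1-fold lower number from compound 2 to compound 3 (0.04 log units; that floor lies within the scatter) is no larger than the usual scatter of repeated measurements, so no clear change is anticipated. For compound 3, the estimated value is 180000 nM, with an expected range from 80000 nM to 300000 nM.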

Compound 3, half-maximal inhibitory concentration: 179000 nM
Beside the measured number, compound 3's estimate is 1.0-fold (0.00 log units) above it; the range from low to high includes it.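

Hydrogen in place of hydroxy on an aromatic carbon gives a 1.1-fold higher number from compound 1 to compound 3 (0.03 log units; within the scatter), so compound 1 and compound 3 cannot be told apart in this assay, and the hydroxy of compound 1 leaves no readable mark on this read-out. Methyl in place of methoxy, on an aromatic carbon meta to a large group, gives an at least 1.1-fold lower number from compound 2 to compound 3 (0.04 log units; that floor lies within the scatter), which is the first reading of this swap, and even this reading shows no change that clears the scatter. That step is only a floor, and the true gap may be larger, because the value of compound 2 is a limit and not a number: the limit of > 200000 nM in this assay, at which 1 of the 3 values shown sits.

From the compounds shown here alone, how far compound 2 really lies from compound 3 therefore stays open, as the step has a lower bound but no upper one. Also open, going by these compounds, is whether another group on this aromatic carbon, such as an amine, a carboxylic acid or a longer chain, would move the number in this assay clearly away from the values seen for compound 1 and compound 3.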